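A few compounds are considered here, and "the series" means these few. Any claim that something is new, unique, unknown or untested is made for them only; others in the source may bear on it.

Three compounds have been measured in an ADME assay on Caco-2 cells (Homo sapiens) for permeability, read by LC-MS, with a stated time of 2 h; on this read-out lower numbers stand for lower permeability and higher numbers for higher permeability:

Compound 1 `CCCN(Cc1ccc(OCCN2C(=O)CCC2=O)c(C)c1)C(CC(=O)O)c1ccc(Cl)cc1`: 10.2 nm/s
Compound 2 `CCCN(Cc1ccc(OCCN2C(=O)CCC2=O)c(C)c1)[C@@H](CC(=O)O)c1ccc(Cl)cc1`: 9.3 nm/s
Compound 3 `Cc1cc(CN(CC2CC2)C(CC(=O)O)c2ccc(Cl)cc2)ccc1OCCN1C(=O)CCC1=O`: 5.2 nm/s

The three numbers lie close together. Compound 3, at 5.2 nm/s, stands within the scatter of both other compounds, so the set shows no clear order in this assay.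

The next compound to be measured is compound 4 `Cc1cc(CN(CC2CC2)[C@@H](CC(=O)O)c2ccc(Cl)cc2)ccc1OCCN1C(=O)CCC1=O`. It differs from compound 3 only in how one centre is drawn: the two compounds have the same atoms and bonds; at least one stereo element is drawn with a configuration in one of them and without one in the other: 1 of 1 stereo elements differ; a stereocentre at a saturated chain carbon is drawn without a configuration in compound 3 and S in compound 4. No group leaves and none enters.

One measured step is of the same kind, with a stereocentre at a saturated chain carbon drawn without a configuration in the first compound and S in the second. This is a 1.1-fold lower number from compound 1 to compound 2 (0.04 log units; within the scatter). The other measured step, a 2.0-fold lower number from compound 1 to compound 3 (0.29 log units; within the scatter), places cyclopropyl in place of ethyl on a saturated chain carbon bound to an amine nitrogen, and this links the pair of compound 3 and compound 4 to the pair of compound 1 and compound 2.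

For the measured compounds named here, with only that single precedent to go on, no change beyond the scatter is expected here. The expected size is a 1.1-fold lower number from compound 3 to compound 4 (0.03 log units; within the scatter). For compound 4 the estimate is 4.8 nm/s, with an expected range from 2.6 nm/s to 9 nm/s.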

Compound 4, apparent permeability: 7.3 nm/s
For compound 4 the middle estimate is 1.5-fold (0.18 log units) below the measured one, within the range that was stated.
By their numbers in this assay, from the lowest: compounds 3, 4, 2 and 1 (each within the scatter of the next).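

In this assay, the second case of a stereocentre at a saturated chain carbon going from no drawn configuration to S gives a 1.4-fold higher number from compound 3 to compound 4 (0.15 log units; within the scatter), so this change has now been read on two cores, and on neither does it pass beyond the scatter. The exchange of cyclopropyl for ethyl on a saturated chain carbon bound to an amine nitrogen can now be read between two compounds drawn as S, where it gives a 1.3-fold lower number from compound 2 to compound 4 (0.11 log units; within the scatter), and the two readings of this exchange agree within their scatter: the same change on two cores in this assay, a 2.0-fold lower number (0.29 log units; within the scatter) from compound 1 to compound 3 and a 1.3-fold lower number (0.11 log units; within the scatter) from compound 2 to compound 4, 1.5-fold (0.19 log units) apart, within the scatter of two such steps At this stereocentre, however, the new step sets a drawn configuration against an undrawn one, not one configuration against its opposite: the fact that one of compounds 3 and 4 is drawn with a defined configuration and the other without, at the place where they differ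

The compounds shown therefore leave open what the R configuration at this centre would give in this assay. Also open, as far as these compounds go, is whether a longer chain in place of cyclopropyl, or an amide in place of the carboxylic acid, would move the number beyond the scatter.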